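Swapping One Phenol-Bearing Aryl for Another

The source may report more compounds than this note shows. Statements on the series, on what has been measured and on what is new or still open speak of the compounds shown alone.

Compound 1 `CN(C)CCn1cnnc1-c1cc(Oc2ccc(NC(=O)N/N=C/c3c(Cl)cccc3Cl)cc2F)ccn1`: 1410 nM in a functional assay on A549 cells (Homo sapiens) for cytotoxicity, read by MTT assay, with a stated time of 72 h; on this read-out lower numbers stand for stronger inhibition and higher numbers for weaker inhibition.
Compound 2 `CN(C)CCn1cnnc1-c1cc(Oc2ccc(NC(=O)N/N=C/c3ccc(F)cc3F)cc2F)ccn1`: 1870 nM in this assay.
Compound 3 `COc1ccc(/C=N/NC(=O)Nc2ccc(Oc3ccnc(-c4nncn4CCN(C)C)c3)c(F)c2)cc1O`: > 100000 nM in this assay, which is a limit of the assay and not a number.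

Compound 3 therefore sits at the weak end of the three; all that is known is that it lies at the limit of > 100000 nM in this assay, at which 1 of the 3 values shown sits. Compound 4 `CN(C)CCn1cnnc1-c1cc(Oc2ccc(NC(=O)N/N=C/c3ccc(O)cc3O)cc2F)ccn1` differs from it in one place: 2,4-dihydroxyphenyl in place of 3-hydroxy-4-methoxyphenyl on a carbon with a double bond to nitrogen. Both measured steps that reach compound 3 bear on this change, since each replaces a halogenated phenyl with the 3-hydroxy-4-methoxyphenyl group: an at least 70-fold higher number from compound 1 to compound 3 (1.85 log units; beyond the scatter) and an at least 53-fold higher number from compound 2 to compound 3 (1.72 log units; beyond the scatter). The halogen-to-hydroxy exchange thus cost a very large amount of potency, while the halogen-to-halogen exchange a 1.3-fold higher number from compound 1 to compound 2 (0.12 log units; within the scatter) changed little. Compound 4 keeps a hydroxylated phenyl on the same carbon, so no recovery toward compound 1 or compound 2 is expected, and there is a fair chance that this assay again reports only a limit for it. The step from the limit of compound 3 is expected to be an at least 1.2-fold lower number from compound 3 to compound 4 (0.09 log units; that floor lies within the scatter). Compound 4 is estimated at 80000 nM, within a range of 15000 nM to 300000 nM.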

Compound 4, half-maximal inhibitory concentration: 12700 nM
Compound 4: the middle estimate sits 6.3-fold (0.80 log units) above what was measured; the measured number lies below the stated range.
By their numbers in this assay, from the lowest: compounds 1 and 2 (each within the scatter of the next); then compound 4. At a limit, above all of these: compound 3.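

Moving from 3-hydroxy-4-methoxyphenyl to 2,4-dihydroxyphenyl on the carbon with a double bond to nitrogen gives an at least 7.8-fold lower number from compound 3 to compound 4 (0.89 log units; beyond the scatter) in this assay, so a phenyl carrying oxygen groups at this position does not by itself mean the near-total loss seen with compound 3; the particular group matters. The halogenated groups still keep a clear lead, with a 6.8-fold higher number from compound 2 to compound 4 (0.83 log units; beyond the scatter) and a 9.0-fold higher number from compound 1 to compound 4 (0.95 log units; beyond the scatter), so 2,4-dihydroxyphenyl wins back only part of what the change away from halogen lost. Compound 3 stands at a limit of the assay and not at a number, so the gain to compound 4 is only a floor: the limit of > 100000 nM in this assay, at which 1 of the 4 values shown sits.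

This single change alters both the kind of oxygen group, methoxy against hydroxy, and the ring numbers that carry those groups, so the compounds shown cannot separate the two effects; a 2-hydroxy-4-methoxyphenyl group would sit directly between compound 3 and compound 4. From the compounds shown here alone, how a 2,4-diaminophenyl group, with amines in place of the hydroxy groups, would compare with the hydroxylated and halogenated groups also remains open.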